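The source may report more compounds than this note shows. Statements on the series, on what has been measured and on what is new or still open speak of the compounds shown alone.

Compounds measured so far:
compound 1 `COc1ccc(/C=C/C(=O)c2ccc(NC(=O)CN3CCN(c4cc5c(cc4F)c(=O)c(C(=O)O)cn5C4CC4)CC3)cc2)cc1` — 2.98 ug/mL in a physicochemical assay for solubility, at pH 6.9; on this read-out higher numbers stand for higher solubility and lower numbers for lower solubility
compound 2 `O=C(CN1CCN(c2cc3c(cc2F)c(=O)c(C(=O)O)cn3C2CC2)CC1)Nc1ccc(C(=O)/C=C/c2cccc([N+](=O)[O-])c2)cc1` — 30.7 ug/mL in this assay

Compound 2 holds the higher of the two numbers in this assay; its nearest neighbour is compound 1, and the step of a 10-fold higher number from compound 1 to compound 2 (1.01 log units; beyond the scatter) separates them. Compound 3 `Cc1ccc(/C=C/C(=O)c2ccc(NC(=O)CN3CCN(c4cc5c(cc4F)c(=O)c(C(=O)O)cn5C4CC4)CC3)cc2)c(C)c1` is not yet measured. It differs from compound 2 in one place: 2,4-dimethylphenyl in place of 3-nitrophenyl on a double-bonded chain carbon bound to a double-bonded chain carbon. Going by the values given here, only one measured step is available, and it bears on this change only indirectly: a 10-fold higher number from compound 1 to compound 2 (1.01 log units; beyond the scatter) shows that exchanging the substituent on the aromatic ring at this position moved the read-out by a large amount, but neither the 2,4-dimethylphenyl group nor a move away from the 3-nitrophenyl group has been measured. The exchange removes the two hydrogen-bond acceptors that the 3-nitrophenyl group carries and brings in a ring with none, so compound 3 is expected to fall well short of compound 2, by roughly the amount an 8.8-fold lower number from compound 2 to compound 3 (0.94 log units; beyond the scatter), landing near the level compound 1 shows. For compound 3 the estimated solubility in this assay is 3.5 ug/mL, within a range from 0.8 ug/mL to 15 ug/mL.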

Compound 3, solubility: 2.12 ug/mL
Compound 3: the middle estimate sits 1.7-fold (0.22 log units) above what was measured; the measured number falls inside the stated range.
By their numbers in this assay, from the lowest: compounds 3 and 1 (each within the scatter of the next); then compound 2.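

In this assay, the earlier large step could have reflected 4-methoxyphenyl as much as 3-nitrophenyl, but a 14-fold lower number from compound 2 to compound 3 (1.16 log units; beyond the scatter) is also large and shows that compound 2 stands apart from a second ring as well, here 2,4-dimethylphenyl, whose substituents hold carbon only. The 4-methoxyphenyl and 2,4-dimethylphenyl groups, on a double-bonded chain carbon bound to a double-bonded chain carbon, give numbers that cannot be told apart, with a 1.4-fold lower number from compound 1 to compound 3 (0.15 log units; within the scatter), so the three compounds form two levels and compound 2 alone occupies the upper one. Nothing available here accounts for this split between the two levels.

The compounds shown leave open whether the upper level belongs to the nitro group specifically or could also be reached with a ring carrying a nitrile, a carboxylic acid or an amine in its place. They also leave open where an unsubstituted phenyl ring would fall, and thus whether the lower level is the baseline for this series or whether the methoxy and methyl groups each hold the number down.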